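Methoxy in place of methyl on compound 2

A few compounds are considered here, and "the series" means these few. Any claim that something is new, unique, unknown or untested is made for them only; others in the source may bear on it.

In a functional assay on KB cells (Homo sapiens) for cytotoxicity, read by MTT assay, with a stated time of 72 h (on this read-out lower numbers stand for stronger inhibition and higher numbers for weaker inhibition), compound 2 `Cc1ccc(S(=O)(=O)c2nc3ccccc3nc2Nc2ccc(F)cc2)cc1` gives 8950 nM and compound 3 `Cc1ccc(S(=O)(=O)c2nc3ccccc3nc2Nc2ccc(C(F)(F)F)cc2)cc1` gives 10300 nM. Going by the values given here, these two stand level, since the only measured step, a 1.2-fold higher number from compound 2 to compound 3 (0.06 log units; within the scatter), lies within the scatter. Compound 1 `COc1cc(Nc2nc3ccccc3nc2S(=O)(=O)c2ccc(C)cc2)cc(OC)c1` adds no number: "not determined" (no result reported).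

Compound 4 `COc1ccc(S(=O)(=O)c2nc3ccccc3nc2Nc2ccc(F)cc2)cc1` carries methoxy in place of methyl on an aromatic carbon, para to a large group: methoxy in place of methyl on an aromatic carbon. Among the compounds with values here, no measured step covers this change. The nearest guide is a 1.2-fold higher number from compound 2 to compound 3 (0.06 log units; within the scatter), a different swap, trifluoromethyl in place of fluoro, and it gives no direction.

No step beyond the scatter is expected in this assay. The expected step is a 1.0-fold higher number from compound 2 to compound 4 (0.00 log units; within the scatter). For compound 4 the estimated value is 9000 nM, with an expected range of 4000 nM to 20000 nM.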

Compound 4, half-maximal inhibitory concentration: 2590 nM
For compound 4 the middle estimate is 3.5-fold (0.54 log units) above the measured one, and the stated range ends above it.
By their numbers in this assay, from the lowest: compound 4; then compounds 2 and 3 (each within the scatter of the next).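

In this assay, going by these compounds alone, the change from 4-methylphenyl to 4-methoxyphenyl gives a 3.5-fold lower number from compound 2 to compound 4 (0.54 log units; beyond the scatter), the first step beyond the scatter. This position therefore responds to a single swap, whereas the earlier swap of trifluoromethyl for fluoro gave only a 1.2-fold higher number from compound 2 to compound 3 (0.06 log units; within the scatter). Nothing available here accounts for the size or direction of this step.

Still open, going by these compounds, is whether methoxy gives a similar step when trifluoromethyl replaces fluoro on the other aromatic ring. Also open, on these data alone, is how an amine or a longer alkoxy chain at this position would compare with methoxy.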